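The source may hold more compounds than are shown below. What is called first, only, known or untested is meant among the compounds shown, and "the series" means these compounds.

Three compounds built on a shared core were tested in a functional assay on HEK293 cells for agonist activity at D(4) dopamine receptor (Homo sapiens), read by FLIPR; on this read-out lower numbers stand for smaller maximal responses and higher numbers for larger maximal responses. Compound 1 `Cc1cc(C)cc(NC(=O)CN2CCC(c3cccc[n+]3[O-])CC2)c1` reaches 76% in this assay. Compound 2 `COc1cccc(C(=O)NCN2CCC(c3cccc[n+]3[O-])CC2)c1C` reaches 51% in this assay. Compound 3 `CCc1cccc(C)c1NC(=O)CN1CCC(c2ccccn2)CC1` reaches 70% in this assay. Among these three numbers, compound 1 carries the highest reading: its gap to compound 3 lies within the usual scatter of such measurements, so the two cannot be told apart, while its gap to compound 2 lies beyond the scatter.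

Compound 4 `O=C(CN1CCC(c2cccc[n+]2[O-])CC1)Nc1cccc(F)c1` has not yet been measured. It differs from compound 1 in one place: 3-fluorophenyl in place of 3,5-dimethylphenyl on an amide-type nitrogen. Among the measured compounds shown here, no step between two measured compounds isolates a change of this kind, so there is no measured precedent for exchanging the group on the amide-type nitrogen. For the measured compounds named here, the only guide is that compound 1 and compound 3, which carry different groups at that nitrogen, give readings close to each other, whereas compound 2 gives the lowest reading. Accordingly the expected change is a number 11 percentage points lower from compound 1 to compound 4 (beyond the scatter), a modest decrease that may well stay within the scatter. Compound 4 is estimated to reach 65% in this assay, with a likely range from 45% to 85%.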

Compound 4, largest response reached (reported as efficacy), in percent of the reference or control that the assay uses: 70%
Beside the measured number, compound 4's estimate is 5 percentage points below it, within the range that was stated.
By their numbers in this assay, from the lowest: compound 2; then compounds 3, 4 and 1 (each within the scatter of the next).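

In this assay, exchanging 3,5-dimethylphenyl for 3-fluorophenyl on the amide-type nitrogen gives a number 6 percentage points lower from compound 1 to compound 4 (within the scatter), the first step measured at this position with everything else in the molecule held constant. Among the compounds shown here, the maximal response therefore does not depend measurably on which of these two aryl groups sits there, something the earlier compounds could not show, as they differ from one another in more than one place. Nothing available explains why the response holds across this exchange.

The step removes both methyl groups and brings in fluorine at once, so the contribution of each part stays unresolved, and a plain phenyl, a cyclohexyl or a group carrying a carboxylic acid on the amide-type nitrogen could still show how far this tolerance extends. On these data alone, it also remains open whether the same exchange gives a comparable step on the core of compound 3.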